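This account rests on a few compounds, and the source may have more. Where it says the series, first, only, none or still open, it means among the compounds named here.

Three analogues sharing one core have been measured in a functional assay on MCF7 cells (Homo sapiens) for antiproliferative activity; a higher number here means a weaker inhibitor, a lower number a stronger inhibitor. Compound 1 `COc1cc(Cc2nc3c(N)nc(F)nc3n2CC2CCCO2)cc(OC)c1OC` gives 22900 nM in this assay. Compound 3 `CCCCn1c(Cc2c(Br)c(OC)c(OC)c(OC)c2Br)nc2c(N)ncnc21` gives 30200 nM in this assay. Compound 2 `CCC(CC)Cn1c(Cc2cc(OC)c(OC)c(OC)c2)nc2c(N)ncnc21` gives 158000 nM in this assay, the highest number of the three, standing beyond the scatter from both compound 3 and compound 1. Among the compounds with values here, none of these three pairs differs in only one place, so no single step between measured compounds can be read from them.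

Compound 4 `CCCCCn1c(Cc2cc(OC)c(OC)c(OC)c2)nc2c(N)ncnc21` is the untested member. It differs from compound 2 by one change: butyl in place of pentan-3-yl on a saturated chain carbon bound to an aromatic nitrogen. Within the data shown here, since no isolated step of this kind exists among the measured compounds, the expectation for it rests on the position of compound 2 alone. Compound 4 is expected to show a modestly lower number than compound 2, a step of a 2.3-fold lower number from compound 2 to compound 4 (0.35 log units; beyond the scatter), the direction favoured because compound 2 stands at 158000 nM and the other two compounds lie lower. The estimate for compound 4 in this assay is 70000 nM, within a range from 20000 nM to 250000 nM.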

Compound 4, half-maximal inhibitory concentration: 61700 nM
Beside the measured number, compound 4's estimate is 1.1-fold (0.05 log units) above it, within the range that was stated.
By their numbers in this assay, from the lowest: compounds 1 and 3 (each within the scatter of the next); then compound 4; then compound 2.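

Read in this assay, the change from 2-ethylbutyl to pentyl gives a 2.6-fold lower number from compound 2 to compound 4 (0.41 log units; beyond the scatter) and is the only step shown that isolates the group on this saturated chain carbon bound to an aromatic nitrogen. Within the data shown here, earlier comparisons each differed in more than one place, whereas this one shows that a change confined to this chain, with the rest of the molecule held constant, is enough to move the number beyond the scatter, though only modestly. Nothing given here explains the direction or size of this step.

From the compounds shown here alone, whether a longer chain such as hexyl, or a chain ending in an amine or a carboxylic acid, would move the number further remains open. The other pairs differ in more than one place, so their steps cannot be read.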